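Oral exposure notes on a two-compound side-chain series

This account rests on a few compounds, and the source may have more. Where it says the series, first, only, none or still open, it means among the compounds named here.

Measured in an ADME assay on the whole organism (strain FVB) for pharmacokinetics, with Mus musculus as the target, read by LC-MS, at a dose of 30 mg/kg by the oral route; a higher number here means more compound in the circulation at the dose given, a lower number less compound in the circulation:
compound 1 `c1cc([C@H]2CC[C@]3(CC2)OOC2(O3)C3CC4CC(C3)CC2C4)ccc1OCCOC1CCNCC1` gives 9180 ng.h/mL
compound 2 `CC(C)(O)CN1CCC(Oc2ccc([C@H]3CC[C@]4(CC3)OOC3(O4)C4CC5CC(C4)CC3C5)cc2)CC1` gives 14200 ng.h/mL

On these numbers, compound 2 stands level with compound 1 in this assay. Among the compounds with values here, the only measured step is a 1.5-fold higher number from compound 1 to compound 2 (0.19 log units; within the scatter).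

Not yet measured is compound 3 `CC(C)(CN)Oc1ccc([C@H]2CC[C@]3(CC2)OOC2(O3)C3CC4CC(C3)CC2C4)cc1`, which differs from compound 2 as follows: 1-(aminomethyl)-1-methylethyl in place of 1-(2-hydroxy-2-methylpropyl)piperidin-4-yl on an oxygen on an aromatic ring. Here 1-(aminomethyl)-1-methylethyl takes the place of 1-(2-hydroxy-2-methylpropyl)piperidin-4-yl on an oxygen on an aromatic ring, so the six-membered non-aromatic ring with 1 hetero atom leaves.

Within the data shown here, compound 1 and compound 2 both carry such a ring, and no measured step covers its loss. The measured step is therefore only an indirect guide. It does show one group exchanged for another on the same oxygen with no change beyond the scatter, so no step beyond the scatter is expected here. The data give no firm direction. The expected size is a 1.6-fold lower number from compound 2 to compound 3 (0.20 log units; within the scatter).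

For compound 3 the estimated value is 9000 ng.h/mL, with an expected range of 3000 ng.h/mL to 27000 ng.h/mL.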

Compound 3, area under the concentration-time curve: 4840 ng.h/mL
Compound 3: middle estimate off by 1.9-fold (0.27 log units), on the high side; the range from low to high includes it.
By their numbers in this assay, from the lowest: compounds 3, 1 and 2 (each within the scatter of the next, the first and the last beyond it).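

In this assay, within the data shown here, 1-(aminomethyl)-1-methylethyl in place of 1-(2-hydroxy-2-methylpropyl)piperidin-4-yl on an oxygen on an aromatic ring gives a 2.9-fold lower number from compound 2 to compound 3 (0.47 log units; beyond the scatter), the first step to lie beyond the scatter, and this change removes the six-membered non-aromatic ring with 1 hetero atom and takes the group from 11 heavy atoms to 5. The same entering group in place of 2-((piperidin-4-yl)oxy)ethyl gives a 1.9-fold lower number from compound 1 to compound 3 (0.28 log units; within the scatter), so loss of the ring does not produce a step beyond the scatter in both comparisons, and the group on this oxygen matters clearly in only one of them. No available measurement bears on what lies behind the difference.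

Loss of the ring cannot be separated from the other changes in the group, as only one group without the ring is shown. On these data alone, it remains open whether an unbranched 2-aminoethyl chain, or a piperidin-4-yl with no substituent on its nitrogen, on the same oxygen would stand nearer compound 2 or compound 3 in this assay.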